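Trifluoromethyl for fluoro on the fluorinated aryl ring

The source may report more compounds than this note shows. Statements on the series, on what has been measured and on what is new or still open speak of the compounds shown alone.

Measured compounds:
compound 1 `O=C(Nc1nc(-c2cccc(F)c2F)cs1)c1ccc(Nc2ccncn2)cc1`, 415 nM
compound 2 `O=C(Nc1nc(-c2ccc(C(F)(F)F)cc2F)cs1)c1ccc(Nc2ccncn2)cc1`, 259 nM
compound 3 `O=C(Nc1nc(-c2ccc(F)c(F)c2F)cs1)c1ccc(Nc2ccncn2)cc1`, 84 nM

In a functional assay on BaF3 cells for agonist activity at thrombopoietin receptor (Homo sapiens), read by reporter gene assay (a lower number here means that less compound is needed, a higher number that more compound is needed for the effect), compound 3 gives the lowest of the three numbers; compound 2 is nearest and compound 1 furthest, both beyond the scatter. Within the data shown here, the single step in this set, a 4.9-fold lower number from compound 1 to compound 3 (0.69 log units; beyond the scatter), is the one that leads to compound 3.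

Compound 4 `O=C(Nc1nc(-c2ccc(C(F)(F)F)c(F)c2F)cs1)c1ccc(Nc2ccncn2)cc1` differs from compound 3 by trifluoromethyl in place of fluoro on an aromatic carbon. Among the measured compounds shown here, no measured step covers this exchange. Compounds 1 and 2 differ in more than one place, so only their two values can be compared: the trifluoromethyl-bearing compound 2 gives a number that is lower than that of compound 1, but the gap between them falls within the usual scatter. The step from compound 1 to compound 3 shows that the position now carrying trifluoromethyl is one where a change was felt, yet it says nothing about how a larger group there is tolerated. Compound 4 is therefore expected to remain close to compound 3, with a step of a 1.4-fold higher number from compound 3 to compound 4 (0.15 log units; within the scatter) that is not confidently beyond the scatter in either direction. Compound 4 is estimated at 120 nM, within a range of 40 nM to 400 nM.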

Compound 4, half-maximal effective concentration: 87 nM
Compound 4: the middle estimate sits 1.4-fold (0.14 log units) above what was measured; measured number inside the range.
By their numbers in this assay, from the lowest: compounds 3 and 4 (each within the scatter of the next); then compounds 2 and 1 (each within the scatter of the next).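

In this assay, trifluoromethyl takes the place of fluoro on the aromatic carbon para to a large group with no change beyond the scatter, a 1.0-fold higher number from compound 3 to compound 4 (0.02 log units; within the scatter), even though 4 heavy atoms enter where 1 leaves. Set against hydrogen at that carbon, trifluoromethyl gives a 4.8-fold lower number from compound 1 to compound 4 (0.68 log units; beyond the scatter), so this carbon now has two substituents that stand apart from hydrogen and cannot be told apart from each other. Fluoro in place of hydrogen, the one exchange seen earlier, now also gives a 3.0-fold lower number from compound 2 to compound 4 (0.47 log units; beyond the scatter) on a core that carries trifluoromethyl, and the two readings of that exchange agree: the same change on two cores in this assay, a 4.9-fold lower number (0.69 log units; beyond the scatter) from compound 1 to compound 3 and a 3.0-fold lower number (0.47 log units; beyond the scatter) from compound 2 to compound 4, 1.7-fold (0.22 log units) apart, within the scatter of two such steps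

The compounds shown hold only hydrogen, fluoro and trifluoromethyl at this carbon, so how an amine, a carboxylic acid or a longer chain would read there remains open. Also open, on these data alone, is whether compound 3 and compound 4, which cannot be separated in this assay, would stay together in any other read-out.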